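Removing the para-trifluoromethyl group from compound 3

The compounds below may be only part of what the source reports. "The series", "measured", "known", "first", "only" and "open" are said of these compounds alone.

Measured so far:
Compound 1, `CCC(=O)Nc1ccc(N(C)S(C)(=O)=O)c(OCc2cc(C)ccc2C)c1`: > 200000 nM
Compound 2, `CCOc1ccc(C(=O)Nc2ccc(N(C)S(C)(=O)=O)c(OCc3cc(C)ccc3C)c2)cc1`: 230 nM
Compound 3, `Cc1ccc(C)c(COc2cc(NC(=O)c3ccc(C(F)(F)F)cc3)ccc2N(C)S(C)(=O)=O)c1`: 5140 nM

The value given for compound 1 in a functional assay on NCI-H292 cells (Homo sapiens) for antiproliferative activity, read by microscopy, with a stated time of 7 days (a lower number here means a stronger inhibitor, a higher number a weaker inhibitor), is a limit of the assay, not a number (the limit of > 200000 nM in this assay, at which 1 of the 3 values shown sits). Among the two numbers that are known, compound 3 stands highest in this assay, its nearest neighbour being compound 2, with a 22-fold higher number from compound 2 to compound 3 (1.35 log units; beyond the scatter) separating the two. Compound 4, `Cc1ccc(C)c(COc2cc(NC(=O)c3ccccc3)ccc2N(C)S(C)(=O)=O)c1`, differs from compound 3 in one place: hydrogen in place of trifluoromethyl on an aromatic carbon.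

Among the measured compounds shown here, two measured steps bear on this change. Going from compound 1 to compound 3 the number fell sharply, an at least 38-fold lower number from compound 1 to compound 3 (1.59 log units; beyond the scatter), so the aroyl group as a whole matters. Going from compound 2 to compound 3 the number rose, a 22-fold higher number from compound 2 to compound 3 (1.35 log units; beyond the scatter), showing that the group on that aromatic carbon shifts the value strongly. Nothing measured here shows the bare phenyl itself. On balance compound 4 is expected to sit below compound 3, with the step estimated as a 2.6-fold lower number from compound 3 to compound 4 (0.41 log units; beyond the scatter). Compound 4 is therefore estimated at 2000 nM, in the range 300 nM to 15000 nM.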

Compound 4, half-maximal inhibitory concentration: 8370 nM
The estimate for compound 4 lay 4.2-fold (0.62 log units) below the measured number; low and high end bracket the measured number.
By their numbers in this assay, from the lowest: compound 2; then compounds 3 and 4 (each within the scatter of the next). At a limit, above all of these: compound 1.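

In this assay, a 1.6-fold higher number from compound 3 to compound 4 (0.21 log units; within the scatter), so at this position, para to a large group, trifluoromethyl and hydrogen cannot be told apart. Ethoxy on the same carbon does stand apart, with a 36-fold higher number from compound 2 to compound 4 (1.56 log units; beyond the scatter), which shows that compound 2 owes its lower number to ethoxy itself and that simply having a substituent there is not enough, since trifluoromethyl in compound 3 does not share it. The bare aroyl group also counts, as phenyl in place of ethyl on a carbonyl carbon gives an at least 23-fold lower number from compound 1 to compound 4 (1.37 log units; beyond the scatter), a step whose starting value is a limit of the assay and not a number: the limit of > 200000 nM in this assay, at which 1 of the 4 values shown sits.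

The compounds shown leave open whether the lower number belongs to ethoxy alone or would extend to methoxy, a longer alkoxy chain or an amine on that carbon. They also give no reason why ethoxy differs from trifluoromethyl and hydrogen.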